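Methyl in place of trifluoromethyl across two core arrangements

A few compounds are considered here, and "the series" means these few. Any claim that something is new, unique, unknown or untested is made for them only; others in the source may bear on it.

Compound 1 `Nc1nc2ccc(C(F)(F)F)cn2c1-c1ccc(O)cc1`, compound 2 `Nc1nc2c(C(F)(F)F)cccn2c1-c1ccc(O)cc1` and compound 3 `Cc1ccc2nc(N)c(-c3ccc(O)cc3)n2c1` have been measured in an assay on isolated protein for inhibition of ubiquitin carboxyl-terminal hydrolase 14 (Homo sapiens); on this read-out higher numbers stand for weaker inhibition and lower numbers for stronger inhibition. Compound 1 reaches only the limit > 100000 nM in this assay. Compound 2 likewise gives only the limit > 100000 nM. Compound 3 also gives only the limit > 100000 nM. From compound 1 to compound 3 the change is methyl in place of trifluoromethyl on an aromatic carbon; the step that the two limits leave unreadable from compound 1 to compound 3 cannot be read, since the limit of > 100000 nM in this assay, at which 3 of the 3 values shown sit, covers both ends. The difference between the cores of compound 1 and compound 2 is not broken down here. Compound 4 `Cc1cccn2c(-c3ccc(O)cc3)c(N)nc12` is not yet measured; it differs from compound 2 by methyl in place of trifluoromethyl on an aromatic carbon, the same kind of change, the carbon here being ortho to a fused ring rather than para to a fused ring. The step of a number no higher from compound 2 to compound 4 (the limit leaves the size open) is expected to remain unreadable, given (the limit of > 100000 nM in this assay, at which 3 of the 3 values shown sit). Compound 4 is expected near 100000 nM, between 30000 nM and 300000 nM, most likely reported again only as a limit.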

Compound 4, half-maximal inhibitory concentration: > 100000 nM
Compound 4: only a limit was reported (the forecaster's own chance of this, stated with the estimate: 85%); the middle value lies on the limit itself.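

No step can be read from compound 2 to compound 4, as both values are limits: the limit of > 100000 nM in this assay, at which 4 of the 4 values shown sit.

The compounds shown leave open whether methyl in place of trifluoromethyl changes inhibition at all on either core.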